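Swapping Chloro for Nitro on a Second Core

This account rests on a few compounds, and the source may have more. Where it says the series, first, only, none or still open, it means among the compounds named here.

Compound 2 `Cc1ccc(/C=C(/SCc2ccc(Cl)cc2)C(=O)c2ccc(Cl)cc2)s1` and compound 3 `Cc1ccc(/C=C(/SCc2ccc(Cl)cc2)C(=O)c2ccc([N+](=O)[O-])cc2)s1` share one core, while compound 1 `COc1ccccc1/C=C(\C(=O)c1ccc(Cl)cc1)S(=O)(=O)Cc1ccc(Cl)cc1` and compound 4 `COc1ccccc1/C=C(\C(=O)c1ccc([N+](=O)[O-])cc1)S(=O)(=O)Cc1ccc(Cl)cc1` share another; the difference between the two cores is not broken down here. Both pairs are joined by one and the same change. From compound 2 to compound 3 the change is nitro in place of chloro on an aromatic carbon. From compound 1 to compound 4 it is nitro in place of chloro on an aromatic carbon. The surroundings of the changed position are described in identical words for both pairs, so the same change has been made on two different cores.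

In a functional assay on DU-145 cells (Homo sapiens) for inhibition, read by trypan blue exclusion, with a stated time of 96 h (a lower number here means a stronger inhibitor of growth, a higher number a weaker inhibitor of growth), compound 2 gives 50000 nM, and compound 3 gives 25000 nM. The step between them is a 2.0-fold lower number from compound 2 to compound 3 (0.30 log units; within the scatter), so the two values cannot be told apart. In this assay compound 1 gives 25000 nM, level with compound 3 at the digits reported and within the scatter of compound 2 as well.

Compound 4 has not yet been measured in this assay. Because a 2.0-fold lower number from compound 2 to compound 3 (0.30 log units; within the scatter) lies within the scatter, a similarly small shift is expected on the second core. The expected step is a 1.4-fold lower number from compound 1 to compound 4 (0.14 log units; within the scatter), again within the scatter. Compound 4 is estimated at 18000 nM, with a likely range from 7000 nM to 50000 nM. With a single earlier example, measured on a different core, this expectation rests on thin ground.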

Compound 4, concentration for 50% growth inhibition: 10000 nM
The estimate for compound 4 lay 1.8-fold (0.26 log units) above the measured number; the range from low to high includes it.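

On the second core, putting nitro in place of chloro gives a 2.5-fold lower number from compound 1 to compound 4 (0.40 log units; beyond the scatter) in this assay, a modest step, but one that can be read on its own, which the step on the first core cannot. Set side by side, the two steps cannot be told apart in size, so within these four compounds the change carries over from one core to the other about as well as this assay can show: the same change on two cores in this assay, a 2.0-fold lower number (0.30 log units; within the scatter) from compound 2 to compound 3 and a 2.5-fold lower number (0.40 log units; beyond the scatter) from compound 1 to compound 4, 1.3-fold (0.10 log units) apart, within the scatter of two such steps This does not make it a rule for the series, since it rests on just two pairs in one cell assay, one of them inside the scatter, and a match in numbers says nothing about why the swap has the effect it has on the second core.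

The compounds shown leave open what other groups at this place on the ring would do, for instance an amine, a carboxylic acid or a nitrile in place of chloro or nitro. They also leave open whether the step from 4-chlorophenyl to 4-nitrophenyl would hold on further cores, or in any read-out other than this assay.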